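Swapping the aryl on the triazole nitrogen of compound 1

The source may report more compounds than this note shows. Statements on the series, on what has been measured and on what is new or still open speak of the compounds shown alone.

Measured so far in an assay on Sf9 cells for inhibition of protein deacetylase HDAC6 (Homo sapiens), read by fluorescence, with a stated time of 40 min, tested at 100 nM; on this read-out higher numbers stand for more inhibition at the one concentration tested (going by the name of the read-out) and lower numbers for less inhibition:
compound 1 `COc1ccc(-n2nc(-c3ccccc3)nc2CNc2ccc(C(=O)NO)cc2)cc1` gives 63.4%
compound 2 `COc1ccc(-n2nc(-c3ccc(O)cc3)nc2CNc2ccc(C(=O)NO)cc2)cc1` gives 70.3%
compound 3 `O=C(NO)c1ccc(NCc2nc(-c3cc4ccccc4s3)nn2-c2ccccc2)cc1` gives 65.5%

Compound 1 sits at the lower end of these three readings, yet the gap to compound 3 and the gap to compound 2 both fall within the scatter, so the three compounds cannot be told apart on this assay. Within the data shown here, the only single-point step measured, a number 6.9 percentage points higher from compound 1 to compound 2 (within the scatter), concerns a hydroxy on the phenyl and lies within the scatter.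

Compound 4 `Cc1cccc(-n2nc(-c3ccccc3)nc2CNc2ccc(C(=O)NO)cc2)c1` differs from compound 1 at another place: 3-methylphenyl in place of 4-methoxyphenyl on an aromatic nitrogen. Among the measured compounds shown here, no measured step touches this aryl group on the ring nitrogen, so nothing among the three compounds speaks to the change directly. For the measured compounds named here, the one step that exists is within the scatter, and the three readings cluster closely. The expected step is therefore a number 1.4 percentage points lower from compound 1 to compound 4 (within the scatter), nothing beyond the scatter in either direction. Compound 4 is estimated at 62%, with a range from 45% to 78%.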

Compound 4, a percentage reported as inhibition, at one concentration (the size of the read-out at that concentration, not a potency): 66%
Compound 4: middle estimate off by 4 percentage points, on the low side, within the range that was stated.
By their numbers in this assay, from the lowest: compounds 1, 3, 4 and 2 (each within the scatter of the next).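

Among these compounds, the swap of 4-methoxyphenyl for 3-methylphenyl on the aromatic nitrogen is the first step measured at this position, and in this assay it comes out as a number 2.6 percentage points higher from compound 1 to compound 4 (within the scatter). The two compounds therefore cannot be told apart, although the aryl group here loses its oxygen and its one hydrogen-bond acceptor, and the substituent on the ring changes its name and place. No available evidence bears on this result.

The step changes the substituent and its place on the aryl ring together, so these compounds do not separate the two; 4-methylphenyl or 3-methoxyphenyl at this position would do so. They also leave open how the reading would respond to a carboxylic acid, an amine or a longer alkyl chain on this aryl group.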